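Adding a Second Fluorinated Group to an Aniline Analogue

The compounds below may be only part of what the source reports. "The series", "measured", "known", "first", "only" and "open" are said of these compounds alone.

The starting point is compound 1, `Oc1nc2nonc2nc1Nc1ccccc1F`. In an assay on mitochondria from L6 cells (Rattus norvegicus) for activation, with a stated time of 90 min (on this read-out higher numbers stand for an effect only at larger amounts of compound and lower numbers for an effect already at smaller amounts), compound 1 gives 12500 nM, the higher of the two numbers recorded, though only by a margin within the scatter. Within the data shown here, the sole comparison available is compound 2, `Oc1nc2nonc2nc1Nc1ccccc1C(F)(F)F`, which in this assay gives 10600 nM; the resulting change is a 1.2-fold lower number from compound 1 to compound 2 (0.07 log units; within the scatter). Compound 3, `Oc1nc2nonc2nc1Nc1ccc(C(F)(F)F)cc1F`, keeps the fluoro group of compound 1 and gains a further group: trifluoromethyl in place of hydrogen on an aromatic carbon. That earlier step also introduced a trifluoromethyl group, yet at a different place on the ring, so it bears on the present change only loosely; since it stayed within the scatter, no step beyond the scatter is expected here either. Compound 3 is accordingly estimated at 10000 nM, with a range from 4000 nM to 30000 nM. This estimate corresponds to an expected 1.3-fold lower number from compound 1 to compound 3 (0.10 log units; within the scatter).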

Compound 3, half-maximal effective concentration: 2600 nM
Estimate against measurement, compound 3: 3.8-fold (0.59 log units) above; the whole stated range lies above it.
By their numbers in this assay, from the lowest: compound 3; then compounds 2 and 1 (each within the scatter of the next).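

In this assay, among these compounds, trifluoromethyl on the aromatic carbon para to a large group and meta to a fluoro group gives a 4.8-fold lower number from compound 1 to compound 3 (0.68 log units; beyond the scatter) and is the first change here to lie beyond the scatter. Trifluoromethyl in place of the fluoro group, by contrast, gave a 1.2-fold lower number from compound 1 to compound 2 (0.07 log units; within the scatter) and did not, so adding this group at the new position is the only change shown that clearly shifts the number, although the two changes also replace different atoms. Nothing available explains why the number falls with this change.

Going by these compounds, whether a methyl group, a chlorine atom, an amine or a carboxylic acid at this carbon would give a step of similar size remains open. Trifluoromethyl appears at this position only alongside the fluoro group, so whether the step would hold without that fluoro group is also unknown.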